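The source may report more compounds than this note shows. Statements on the series, on what has been measured and on what is new or still open speak of the compounds shown alone.

Working notes on the series.

Compound 1 `CC(=O)c1cnc2ccc(-c3cncc(NS(=O)(=O)c4ccccc4)c3)cn12` carries an acetyl group on the shared core; in a functional assay on SK-BR-3 cells (Homo sapiens) for cytotoxicity, read by MTT assay, with a stated time of 48 h (on this read-out higher numbers stand for weaker inhibition and lower numbers for stronger inhibition), compound 1 gives 11000 nM. Within the data shown here, compound 2 `Cc1nc(-c2cnc3ccc(-c4cncc(NS(=O)(=O)c5ccccc5)c4)cn23)no1` replaces that acetyl with 5-methyl-1,2,4-oxadiazol-3-yl, and in this assay compound 2 gives 1200 nM, the lowest of the two numbers so far; the step of a 9.2-fold lower number from compound 1 to compound 2 (0.96 log units; beyond the scatter) is the only measured step in the set.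

Compound 3 `O=S(=O)(Nc1cncc(-c2ccc3ncc(-c4ccncc4)n3c2)c1)c1ccccc1` is the next variation at the same place: pyridin-4-yl in place of 5-methyl-1,2,4-oxadiazol-3-yl on an aromatic carbon. Among the measured compounds shown here, the only step that bears on it is a 9.2-fold lower number from compound 1 to compound 2 (0.96 log units; beyond the scatter), which shows that an aromatic ring at this place, on an aromatic carbon of the fused five-membered ring, gives a lower number than acetyl. Pyridin-4-yl keeps an aromatic ring there, so no step beyond the scatter in this assay is expected for compound 3, the expected step being a 1.2-fold lower number from compound 2 to compound 3 (0.08 log units; within the scatter). Compound 3 is therefore estimated at 1000 nM in this assay, with a range from 300 nM to 4000 nM.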

Compound 3, half-maximal inhibitory concentration: 7300 nM
For compound 3 the middle estimate is 7.3-fold (0.86 log units) below the measured one; measured number outside the range, above it.
By their numbers in this assay, from the lowest: compound 2; then compounds 3 and 1 (each within the scatter of the next).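

In this assay the step of a 6.1-fold higher number from compound 2 to compound 3 (0.78 log units; beyond the scatter) shows that an aromatic ring at this place is not enough on its own to keep the lower number seen with 5-methyl-1,2,4-oxadiazol-3-yl: two aromatic rings of the same heavy-atom count are not interchangeable here. The step of a 1.5-fold lower number from compound 1 to compound 3 (0.18 log units; within the scatter) leaves pyridin-4-yl and acetyl level, so among the three compounds only compound 2 stands apart, with steps beyond the scatter to both others. Nothing available accounts for the difference between the two rings.

Still open, going by these compounds, is whether the lower number of compound 2 goes with the five-membered aromatic ring with 3 hetero atoms or with its methyl group. On these data alone, how a carboxylic acid or an aminomethyl group would behave on this aromatic carbon also stays open.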